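The compounds below may be only part of what the source reports. "The series", "measured", "known", "first", "only" and "open" are said of these compounds alone.

Measured compounds in the series so far:

compound 1 `COc1ccccc1N1C(=O)C(C)SC1c1cccc(C(=O)NCCCCc2ccccc2)c1`: 94%
compound 2 `COc1ccccc1N1C(=O)CSC1c1cc(F)cc(C(=O)O)c1`: 0%
compound 3 `O=C(NCCCCc1ccccc1)c1cccc(C2SCC(=O)N2c2cccc(F)c2)c1`: 92%

In a functional assay on MG-63 cells (Homo sapiens) for inhibition, read by CCK-8 assay, with a stated time of 72 h, tested at 1 uM (a higher number here means more inhibition at the concentration tested (going by the name of the read-out), a lower number less inhibition), compound 1 gives 94% and compound 3 gives 92%; the two numbers lie within the scatter of each other, so no order between them can be read. Among the compounds with values here, compound 2, the only member without the amide chain, gives 0% in this assay, a gap to compound 3 that is well beyond the scatter. Compound 3 thus sits close to compound 1 and far above compound 2 on the numbers shown.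

The next compound, compound 4 `O=C(NCCCCc1ccccc1)c1cccc(C2SCC(=O)N2c2ccccc2)c1`, has not been measured in this assay. Against compound 3 it shows the change (hydrogen in place of fluoro on an aromatic carbon), that is, the 3-fluorophenyl becomes a plain phenyl while the amide chain of compound 3 is kept. Within the data shown here, no measured pair in the set isolates this change, so its size is unknown. Since compound 3 gives 92% and the closely related compound 1 gives 94%, the step of a number 4 percentage points lower from compound 3 to compound 4 (within the scatter) is expected to be small and not beyond the scatter, if anything a slight decline. Compound 4 is therefore estimated at 88% in this assay, with a range from 70% to 98%.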

Compound 4, a percentage reported as inhibition, at one concentration (the size of the read-out at that concentration, not a potency): 89%
Compound 4: the middle estimate sits 1 percentage points below what was measured; the measured number falls inside the stated range.
By their numbers in this assay, from the lowest: compound 2; then compounds 4, 3 and 1 (each within the scatter of the next).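

In this assay, within the data shown here, the change from 3-fluorophenyl to phenyl gives the first single-place step, a number 3 percentage points lower from compound 3 to compound 4 (within the scatter), and it shows that the fluoro on this aromatic carbon can be replaced by hydrogen without a step beyond the scatter while the amide chain is kept. With compound 4 at 89% in this single-concentration read-out, the series stays near the top of the percentage scale, so a real difference in potency between the fluoro and hydrogen forms could go unseen here. No measured property bears on this step, and the data offer no account of its size.

Still open, going by these compounds, is whether the inhibition in this assay is higher, lower or level with groups of a different kind, such as an amine, a carboxylic acid or a trifluoromethyl, in place of the fluoro on this ring. Among these compounds, compound 1 and compound 2 differ from compound 4 in more than one place, so no step to either can be read, and the role of the amide chain remains to be tested with a shorter or longer chain on an otherwise unchanged compound.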